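Moving a methoxy group on a weak inhibitor

The source may hold more compounds than are shown below. What is called first, only, known or untested is meant among the compounds shown, and "the series" means these compounds.

In a physicochemical assay, read by spectrophotometry, with a stated time of 60 min (on this read-out higher numbers stand for weaker inhibition and lower numbers for stronger inhibition), compound 1 `COc1ccccc1-n1c(S)nnc1CSCc1cc(C(C)(C)C)c(O)c(C(C)(C)C)c1` reaches only a limit, > 100000 nM, and gives no number. Compound 1 therefore stands at the limit of > 100000 nM in this assay, at which 1 of the 2 values shown sits. Compound 2 `COc1ccc(NC(=S)NNC(=O)CSCc2cc(C(C)(C)C)c(O)c(C(C)(C)C)c2)cc1` does give a number in this assay, 50900 nM.

The next compound, compound 3 `COc1ccc(-n2c(S)nnc2CSCc2cc(C(C)(C)C)c(O)c(C(C)(C)C)c2)cc1`, has the same atoms as compound 1, joined differently: 4-methoxyphenyl in place of 2-methoxyphenyl on an aromatic nitrogen. It carries 4-methoxyphenyl in place of 2-methoxyphenyl on an aromatic nitrogen, and the rest of the core of compound 1 stays as it is. Among the measured compounds shown here, no measured pair of compounds shows what such a move does, so the expectation has little to rest on. A small change is expected at most, perhaps none beyond the scatter, and any shift should run toward stronger inhibition. The estimated step is an at least 1.1-fold lower number from compound 1 to compound 3 (0.04 log units; that floor lies within the scatter). For the measured compounds named here, the only number available nearby is that of compound 2 at 50900 nM, and it sets the expected lower side of the range. For compound 3 the estimate is 90000 nM, with an expected range from 35000 nM to 200000 nM, and the read-out may again turn out to be only a limit.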

Compound 3, half-maximal inhibitory concentration: 92700 nM
Estimate against measurement, compound 3: 1.0-fold (0.01 log units) below, and the stated range covers the measured number.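

Compound 3 gives the shared core a measured number in this assay, which compound 1 does not provide. The move from 2-methoxyphenyl to 4-methoxyphenyl on the aromatic nitrogen can be read only as an at least 1.0-fold lower number from compound 1 to compound 3 (0.03 log units; that floor lies within the scatter), so this floor shows no effect that can be told apart from the scatter. The true step may be larger, because one end of it rests on a limit and not on a number: the limit of > 100000 nM in this assay, at which 1 of the 3 values shown sits.

The compounds shown leave open how large that step really is, and whether this position responds at all to anything other than a shift of the methoxy group around the same aromatic ring. An amine, a carboxylic acid or a longer chain such as ethoxy in place of the methoxy group would test that on the same core, and replacing the sulfanyl group on the neighbouring ring atom remains a separate question.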